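This account rests on a few compounds, and the source may have more. Where it says the series, first, only, none or still open, it means among the compounds named here.

Within the data shown here, in a physicochemical assay for solubility, read by LC-MS, in phosphate buffer, with a stated time of 24 h, at pH 7.4 (on this read-out lower numbers stand for lower solubility and higher numbers for higher solubility), compound 2 `CC(=O)Nc1cc(Nc2cc(NC3CC3)n3ncc(C#N)c3n2)ccc1N1CC[C@H](N)C1` gives 590000 nM, the only actual number so far. Compound 1 `CCN(CC)CCN(C)c1ccc(Nc2cc(NC3CC3)n3ncc(C#N)c3n2)cc1NC(C)=O` reads > 1000000 nM, which is a limit of the assay and not a number.

Compound 3 `CC(=O)Nc1cc(Nc2cc(NC3CC3)n3ncc(C#N)c3n2)ccc1N1CC[C@@H](N)C1` has not yet been measured. Its difference from compound 2 is this: the two compounds have the same atoms and bonds and differ only in configuration as drawn: 1 of 1 stereo elements differ; a stereocentre at a saturated ring carbon is drawn S in compound 2 and R in compound 3. The two compounds have the same atoms and bonds, and only the stereocentre at a saturated ring carbon changes, drawn S in compound 2 and R in compound 3.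

Among the measured compounds shown here, only one measured step is available, an at least 1.6-fold lower number from compound 1 to compound 2 (0.22 log units; that floor lies within the scatter). That step places 3-aminopyrrolidin-1-yl where (2-(diethylamino)ethyl)(methyl)amino stood, so it changes the atoms themselves and gives no measured size for a change in configuration alone. With the same atoms and bonds as compound 2 at 590000 nM, compound 3 is expected to show no step in either direction beyond the scatter in this assay. The expected step is small: a 1.0-fold higher number from compound 2 to compound 3 (0.01 log units; within the scatter). Compound 3 is estimated at about 600000 nM, with an expected range from 300000 nM to 1000000 nM.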

Compound 3, solubility: 812000 nM
Compound 3: the middle estimate sits 1.4-fold (0.13 log units) below what was measured; the measured number falls inside the stated range.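

Among these compounds, a first size for a change of configuration alone is now available: a 1.4-fold higher number from compound 2 to compound 3 (0.14 log units; within the scatter) in this assay, on the carbon of the 3-aminopyrrolidin-1-yl ring that carries the amine. At this position, then, the two drawn configurations cannot be told apart on this read-out, and neither can be ranked above the other, so the stereocentre gives no measured handle on solubility in this pair. The second configuration also offers a new comparison with the open (2-(diethylamino)ethyl)(methyl)amino chain, an at least 1.2-fold lower number from compound 1 to compound 3 (0.09 log units; that floor lies within the scatter), but this gives only a floor and not a true size, because compound 1 sits at a limit of the assay, not at a number: the limit of > 1000000 nM in this assay, at which 1 of the 3 values shown sits.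

As far as these compounds go, how far compound 1 truly lies from compound 2 and compound 3 therefore remains unknown, and so does whether the choice between the ring and the open chain matters on this read-out at all. Also open, from the compounds shown here alone, is whether a hydroxyl group or a carboxylic acid in place of the ring amine, at either configuration of that carbon, would leave the number within the scatter or move it beyond.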